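A few compounds are considered here, and "the series" means these few. Any claim that something is new, unique, unknown or untested is made for them only; others in the source may bear on it.

The measured compounds:

compound 1 `Cc1cc2ncn(-c3ccc4c(N)nc(N)nc4c3)c2cc1C`: 1610 nM
compound 2 `Cc1cc2nc(-c3ccco3)n(-c3ccc4c(N)nc(N)nc4c3)c2cc1C`: 943 nM
compound 3 `Cc1cc2nc(-c3cccs3)n(-c3ccc4c(N)nc(N)nc4c3)c2cc1C`: 1030 nM

All three were tested in an assay on isolated protein for inhibition of Dihydrofolate reductase (Homo sapiens), read by spectrophotometry, using NADPH, with a stated time of 10 min; a lower number here means a stronger inhibitor, a higher number a weaker inhibitor. Compound 1 carries the highest number of the three, but neither of its companions stands apart from it: a 1.7-fold lower number from compound 1 to compound 2 (0.23 log units; within the scatter) and a 1.6-fold lower number from compound 1 to compound 3 (0.19 log units; within the scatter) are both small, and so is a 1.1-fold higher number from compound 2 to compound 3 (0.04 log units; within the scatter). On these numbers the three compounds are not distinguishable from one another.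

Compound 4 `Cc1cc2nc(C3CCOC3)n(-c3ccc4c(N)nc(N)nc4c3)c2cc1C` is the next compound to be measured. It differs from compound 1 in one place: oxolan-3-yl in place of hydrogen on an aromatic carbon. The two measured steps that bear on this change are those from compound 1 to compound 2 and from compound 1 to compound 3, since each of them also places a five-membered ring on the same aromatic carbon of the shared core, and each of them moved the number only a little, as shown by a 1.7-fold lower number from compound 1 to compound 2 (0.23 log units; within the scatter) and a 1.6-fold lower number from compound 1 to compound 3 (0.19 log units; within the scatter). Nothing in the data sets the oxolan-3-yl group apart from those two rings at this position.

Compound 4 is therefore expected to stay close to compound 1, with a step of a 1.3-fold lower number from compound 1 to compound 4 (0.13 log units; within the scatter) that lies within the scatter. The estimate for compound 4 is 1200 nM, with a range from 500 nM to 2800 nM.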

Compound 4, inhibition constant: > 5000 nM
Compound 4 was reported as a limit; the forecaster's own chance of this, stated with the estimate: 3%; middle value at least 4.1-fold (0.61 log units) from the limit.
By their numbers in this assay, from the lowest: compounds 2, 3 and 1 (each within the scatter of the next). At a limit, above all of these: compound 4.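

In this assay compound 4 is reported only as a limit: the limit of > 5000 nM in this assay, at which 1 of the 4 values shown sits. Even so, the result shows that this aromatic carbon, between two ring nitrogen atoms, does not treat all five-membered rings alike: where furan-2-yl and thiophen-2-yl stayed within the scatter of hydrogen, oxolan-3-yl gives an at least 3.1-fold higher number from compound 1 to compound 4 (0.49 log units; beyond the scatter), and it also separates from the two aromatic rings, with an at least 4.8-fold higher number from compound 3 to compound 4 (0.68 log units; beyond the scatter) and an at least 5.3-fold higher number from compound 2 to compound 4 (0.72 log units; beyond the scatter). Compounds 1, 2 and 3 alone gave no sign of this sensitivity to the group placed here, and the data shown give no cause for it.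

As far as these compounds go, how far the true value of compound 4 lies past its limit remains open, so the size of these steps is fixed only from one side. Also open, from the compounds shown here alone, is whether the change belongs to the ring oxygen, to the non-aromatic ring as such, or to the point of attachment, a question that a cyclopentyl ring, a pyrrolidine or an oxolan-2-yl group at the same carbon would bear on.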